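The source may report more compounds than this note shows. Statements on the series, on what has been measured and on what is new or still open speak of the compounds shown alone.

Compound 1 `O=C(Nc1cc(-c2ccccc2)nn1-c1ccccc1)c1ccccc1` is the reference of the series. For the measured compounds named here, in a functional assay on cells for positive allosteric modulation of metabotropic glutamate receptor 5 (Rattus norvegicus), read by calcium flux (on this read-out higher numbers stand for an effect only at larger amounts of compound and lower numbers for an effect already at smaller amounts), compound 1 gives 203 nM, the highest of the three numbers measured so far. Compound 2 `COc1cccc(C(=O)Nc2cc(-c3ccccc3)nn2-c2ccccc2)c1` gives 102 nM, and the step of a 2.0-fold lower number from compound 1 to compound 2 (0.30 log units; within the scatter) stays within the scatter. Compound 3 `O=C(Nc1cc(-c2ccccc2)nn1-c1ccccc1)c1cccc([N+](=O)[O-])c1` gives 39 nM; the step of a 5.2-fold lower number from compound 1 to compound 3 (0.72 log units; beyond the scatter) is modest but beyond the scatter, as is the step of a 2.6-fold lower number from compound 2 to compound 3 (0.42 log units; beyond the scatter).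

Compound 4 `O=C(Nc1cc(-c2ccccc2Cl)nn1-c1ccccc1)c1ccccc1` differs from compound 1 by chloro in place of hydrogen on an aromatic carbon. Going by the values given here, none of the measured steps bears directly on this change: each of them substitutes a different aromatic ring from the one altered in compound 4, and no measured pair varies that ring at all. The measured steps show that a single substituent on an aromatic carbon can shift the number modestly or leave it within the scatter, but give no direction for this position. In this assay the step from compound 1 to compound 4 is therefore expected to be a 1.1-fold lower number from compound 1 to compound 4 (0.05 log units; within the scatter), with no change beyond the scatter. Compound 4 is estimated at 180 nM, in a range from 60 nM to 550 nM.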

Compound 4, half-maximal effective concentration: 2290 nM
Compound 4: the middle estimate sits 13-fold (1.10 log units) below what was measured; the measured number lies above the stated range.
By their numbers in this assay, from the lowest: compound 3; then compounds 2 and 1 (each within the scatter of the next); then compound 4.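

In this assay, for the compounds shown here, the phenyl to 2-chlorophenyl change gives the first measured variation of this ring, and an 11-fold higher number from compound 1 to compound 4 (1.05 log units; beyond the scatter) is the only step so far towards a higher number. The earlier substituent changes, made on a different ring, gave lower numbers or stayed within the scatter, so they did not show that one chlorine atom on an aromatic carbon, ortho to a large group, can cost this much on the read-out. No measurement at hand offers an explanation for this step.

From the compounds shown here alone, it remains open whether this loss belongs to chloro itself or to any group at this place, such as fluoro, methyl, methoxy or an amine. Also open, going by these compounds, is how chloro behaves elsewhere on this ring or on the other aromatic rings of the shared core.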